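The compounds below may be only part of what the source reports. "The series", "measured", "known", "first", "only" and "open" are said of these compounds alone.

In a functional assay on HepG2 cells (Homo sapiens) for antiproliferative activity, read by MTT assay, with a stated time of 48 h (a lower number here means a stronger inhibitor, a higher number a weaker inhibitor), compound 1 `COc1ccc(CN(C(=O)Cn2cc(COc3ccc4ccc(=O)oc4c3)nn2)c2cc(OC)c(OC)c(OC)c2)cc1` gives 1300 nM. Compound 2 `COc1ccc(CN(C(=O)Cn2cc(CSc3nncs3)nn2)c2cc(OC)c(OC)c(OC)c2)cc1` gives 38600 nM, the higher of the two numbers and so the weaker result. Compound 3 `COc1ccc(CN(C(=O)Cn2cc(CSc3nnnn3C)nn2)c2cc(OC)c(OC)c(OC)c2)cc1` differs from it by 1-methyl-1H-tetrazol-5-yl in place of 1,3,4-thiadiazol-2-yl on a sulfur. Among the compounds with values here, the only measured step, a 30-fold higher number from compound 1 to compound 2 (1.47 log units; beyond the scatter), exchanged a much larger group, so it is a weak guide to this swap of one small ring for another. No step beyond the scatter is expected in this assay, and the estimate is a 1.1-fold lower number from compound 2 to compound 3 (0.04 log units; within the scatter). Compound 3 is expected at 35000 nM, with an estimated range from 12000 nM to 90000 nM.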

Compound 3, half-maximal inhibitory concentration: 28300 nM
The estimate for compound 3 lay 1.2-fold (0.09 log units) above the measured number; the measured number falls inside the stated range.
By their numbers in this assay, from the lowest: compound 1; then compounds 3 and 2 (each within the scatter of the next).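

In this assay, 1-methyl-1H-tetrazol-5-yl in place of 1,3,4-thiadiazol-2-yl on the sulfur gives a 1.4-fold lower number from compound 2 to compound 3 (0.13 log units; within the scatter) and so does not separate these two small rings. The group in compound 1 still stands apart from this new ring, with a 22-fold higher number from compound 1 to compound 3 (1.34 log units; beyond the scatter) in the same assay. Nothing measured here gives a reason for either result.

A plain phenyl ring on the sulfur, or a small ring bearing an amine or a carboxylic acid, remains untested in the compounds shown. Going by these compounds, whether either would come closer to compound 1 stays open.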